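The compounds below may be only part of what the source reports. "The series", "measured", "known", "first", "only" and "open" are said of these compounds alone.

Three amides of two closely related bicyclic diamines have been measured so far. Compound 1 `O=C(C1CC1)N1CC2CC1CN2` gives 10000 nM in an assay on CHO cells for displacement of a labelled ligand from Neuronal acetylcholine receptor; alpha3/alpha6/beta2/beta3 (Homo sapiens), read by scintillation counting; on this read-out higher numbers stand for weaker inhibition and lower numbers for stronger inhibition. Compound 2 `O=C(C1CCCC1)N1CC2CC(C1)N2` gives 2900 nM in this assay, and compound 3 `O=C([C@@H]1C[C@@H]1F)N1CC2CC(C1)N2` gives 55 nM. On these numbers compound 3 stands lowest of the three: the nearest is compound 2, whose number is beyond the scatter above it, and the furthest is compound 1.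

The next compound, compound 4 `C[C@H]1C[C@H]1C(=O)N1CC2CC(C1)N2`, differs from compound 3 in one place: methyl in place of fluoro on a saturated ring carbon of the three-membered non-aromatic ring of carbon only, so that the 2-fluorocyclopropyl group becomes 2-methylcyclopropyl. Among the compounds with values here, no pair among the measured compounds shows this change, so its effect is unknown here. Because compound 3 reaches 55 nM, the expectation for compound 4 is a modest rise, a step from compound 3 to compound 4 of a 2.7-fold higher number from compound 3 to compound 4 (0.44 log units; beyond the scatter), likely at or somewhat beyond the scatter. Compound 4 is thus estimated at 150 nM, within a range of 30 nM to 800 nM.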

Compound 4, inhibition constant: 170 nM
Compound 4: the middle estimate sits 1.1-fold (0.05 log units) below what was measured; measured number inside the range.
By their numbers in this assay, from the lowest: compound 3; then compound 4; then compound 2; then compound 1.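

Within the data shown here, replacing fluoro with methyl on a saturated ring carbon of the three-membered ring gives, in this assay, a 3.1-fold higher number from compound 3 to compound 4 (0.49 log units; beyond the scatter), the only change in this set that can be read in one place. It shows that the number responds to the group at this position, with fluoro on the lower side of the pair, and that the 2-methylcyclopropyl amide loses only a modest step against the 2-fluorocyclopropyl amide. Nothing measured here accounts for this step.

On these data alone, it remains open how other groups at this carbon, such as chloro, hydroxyl, trifluoromethyl or an amine, would compare with fluoro and methyl. As far as these compounds go, it is also open where the cyclopropyl amide carrying no group at this carbon would stand on the core of compound 3.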